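A few compounds are considered here, and "the series" means these few. Any claim that something is new, unique, unknown or untested is made for them only; others in the source may bear on it.

Compound 1 `COc1cc(C(=N)N)ccc1-c1cc2ccc(C(=N)N)cc2o1` gives 108000 nM in an ADME assay on L6 cells (Rattus norvegicus) for cytotoxicity; on this read-out higher numbers stand for weaker inhibition and lower numbers for stronger inhibition. Compound 3 `N=C(N)c1ccc(-c2cc3ccc(C(=N)N)cc3o2)c(O)c1` reaches only a limit of this assay, > 221000 nM. The change from compound 1 to compound 3, (hydrogen in place of methyl on an oxygen on an aromatic ring), yields an at least 2.0-fold higher number from compound 1 to compound 3 (0.31 log units; beyond the scatter); the step is open-ended because of the limit of > 221000 nM in this assay, at which 1 of the 3 values shown sits. Compound 2 `COc1ccc(C(=N)NC(C)C)cc1-c1cc2ccc(C(=N)NC(C)C)cc2o1` likewise reaches only a limit of this assay, > 175000 nM. How the core of compound 2 differs from that of compound 1 is not broken down here. Compound 4 `CC(C)NC(=N)c1ccc(O)c(-c2cc3ccc(C(=N)NC(C)C)cc3o2)c1` carries the same change, (hydrogen in place of methyl on an oxygen on an aromatic ring). Beside the earlier step, a step that the limit leaves unreadable from compound 2 to compound 4 is expected, resting on compound 2 already sitting at a limit (the limit of > 175000 nM in this assay, at which 1 of the 3 values shown sits). Compound 4 is therefore expected to give about 260000 nM, between 150000 nM and 500000 nM, in this assay, most likely reported only as a limit.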

Compound 4, half-maximal inhibitory concentration: > 187000 nM
Compound 4: no number, only a limit (the forecaster's own chance of this, stated with the estimate: 85%); the middle value is on the limit's open side.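

Compound 2 and compound 4 both sit at limits of this assay, so no step can be read between them. The compounds shown leave open whether methoxy to hydroxy raises the number for compound 4 as it does for compound 3.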